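The source may hold more compounds than are shown below. What is called first, only, known or untested is meant among the compounds shown, and "the series" means these compounds.

In a functional assay on T98 cells (Homo sapiens) for cytotoxicity, read by MTT assay, with a stated time of 48 h (a lower number here means a stronger inhibitor, a higher number a weaker inhibitor), compound 1 `NC(=S)N/N=C(\N)c1ccccn1` gives 3600 nM, while compound 2 `CCNC(=S)N/N=C(\N)c1ccccn1` gives 143000 nM, the higher of the two numbers. Compound 3 `CNC(=S)N/N=C(\N)c1ccccn1` has not yet been measured. It departs from compound 2 by hydrogen in place of methyl on a saturated chain carbon bound to an amide-type nitrogen, so that ethyl becomes methyl. For the measured compounds named here, only one measured step bears on this change: a 40-fold higher number from compound 1 to compound 2 (1.60 log units; beyond the scatter), a large step with ethyl in place of hydrogen on an amide-type nitrogen. Ethyl to methyl goes part of the way back along that step, although no measured compound shows how much. A sizeable move to a lower number is therefore expected in this assay, probably beyond the scatter. The expected change is a 7.2-fold lower number from compound 2 to compound 3 (0.85 log units; beyond the scatter). For compound 3, the estimated value is 20000 nM, within an expected range of 5000 nM to 90000 nM.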

Compound 3, half-maximal inhibitory concentration: 32000 nM
Compound 3: middle estimate off by 1.6-fold (0.20 log units), on the low side, within the range that was stated.
By their numbers in this assay, from the lowest: compound 1; then compound 3; then compound 2.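

In this assay, the earlier pair gave only the whole step from hydrogen to ethyl on this nitrogen, and the methyl compound now divides it into two parts. Going from ethyl to methyl gives a 4.5-fold lower number from compound 2 to compound 3 (0.65 log units; beyond the scatter), while putting methyl in place of hydrogen gives an 8.9-fold higher number from compound 1 to compound 3 (0.95 log units; beyond the scatter), so that both parts lie beyond the scatter and even the single carbon of methyl separates compound 3 from compound 1. The numbers thus rise in turn from hydrogen through methyl to ethyl, but nothing available explains this order.

From the compounds shown here alone, whether a propyl group or a longer chain would continue this rise remains open. So does whether a hydroxyl or an amine at the end of such a chain, or a phenyl ring on this nitrogen, would fit the same order.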